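Swapping Bromo for Methyl in a Cell Growth Inhibitor Series

A few compounds are considered here, and "the series" means these few. Any claim that something is new, unique, unknown or untested is made for them only; others in the source may bear on it.

Compound 1 `O=C1Nc2ccc(Br)cc2/C1=N/NC(=S)N/N=C/c1ccc(-c2ccccc2)cc1`: in a functional assay on HeLa cells (Homo sapiens) for inhibition, read by MTT assay (on this read-out lower numbers stand for stronger inhibition and higher numbers for weaker inhibition), compound 1 gives 3250 nM.
Compound 2 `Cc1ccc(O)c(/C=N/NC(=S)N/N=C2\C(=O)Nc3ccc(Br)cc32)c1`: compound 2 reaches only the limit > 50000 nM in this assay.
Compound 3 `Cc1ccc(O)c(/C=N/NC(=S)N/N=C2\C(=O)Nc3ccc(C)cc32)c1`: compound 3 likewise reaches only the limit > 50000 nM.

Compound 3 comes from compound 2 by the change (methyl in place of bromo on an aromatic carbon). Both values are limits rather than numbers, so the step that the two limits leave unreadable from compound 2 to compound 3 cannot be read, because of the limit of > 50000 nM in this assay, at which 2 of the 3 values shown sit. The cores of compound 1 and compound 2 differ in more than one place, and that difference is not broken down here.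

Compound 4 `Cc1ccc2c(c1)/C(=N/NC(=S)N/N=C/c1ccc(-c3ccccc3)cc1)C(=O)N2` has not yet been measured. It comes from compound 1 by the same kind of change, (methyl in place of bromo on an aromatic carbon). Since the measured step between compound 2 and compound 3 gives no usable size, the expectation for compound 4 rests on the value of compound 1, 3250 nM, and on the smallness of the group exchanged. The step of a 1.1-fold higher number from compound 1 to compound 4 (0.03 log units; within the scatter) is expected to stay within the usual scatter. Compound 4 is therefore estimated at 3500 nM, most likely between 1000 nM and 12000 nM.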

Compound 4, half-maximal inhibitory concentration: > 50000 nM
Compound 4 gave a limit, no number; the forecaster's own chance of this, stated with the estimate: 10%; middle value at least 14-fold (1.15 log units) away from the limit.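

In this assay, exchanging bromo for methyl on the core of compound 1 gives an at least 15-fold higher number from compound 1 to compound 4 (1.18 log units; beyond the scatter), so on this core the swap of one heavy atom for another is far from neutral. From the compounds shown here alone, compound 4 reaches only a limit of the assay, > 50000 nM, so this step is a minimum and its true size stays unknown. The same change from compound 2 to compound 3 cannot be read because both compounds sit at a limit, so one core gives a large step, the other gives no reading, and whether the effect carries from one core to the other stays undecided: the limit of > 50000 nM in this assay, at which 3 of the 4 values shown sit.

Going by these compounds, only bromo and methyl appear at this place on the core of compound 1, so it remains open whether another group, such as chloro or methoxy, would keep a measurable value there. Also open, on these data alone, is whether any compound on the core of compound 2 can give a number in this assay, which a readable step on that core would need.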